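The compounds below may be only part of what the source reports. "The series", "measured", "known", "first", "only" and "open" are said of these compounds alone.

Of the compounds shown here, two have been measured in a functional assay on the whole organism (strain Wistar) for inhibition, with Rattus norvegicus as the target, read by paw edema, with stated times of 1 h and 2 h, at a dose of 10 mg/kg by the intraperitoneal route; on this read-out higher numbers stand for more inhibition at the one dose given (going by the name of the read-out) and lower numbers for less inhibition. Compound 1, with the structure `CC(=O)Nc1ccc(O)c(C(=O)OCCn2c([N+](=O)[O-])cnc2C)c1`, gives 24.5% in this assay. Compound 2, built as `Cc1ncc([N+](=O)[O-])n1CCOC(=O)c1cc(NC(=O)[C@H](CCCCN)NC(=O)OCc2ccccc2)ccc1O`, gives 37.8%. Within the data shown here, of the two numbers, compound 2 stands highest; the only other compound, compound 1, lies lower by a gap that is beyond the usual scatter of this measurement. Among the measured compounds shown here, no step between measured compounds that differ in a single place has been recorded, so the two values can only be set side by side.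

Compound 3, with the structure `Cc1ncc([N+](=O)[O-])n1CCOC(=O)c1cc(NC(=O)CNC(=O)OCc2ccccc2)ccc1O`, has not yet been measured in this assay. It differs from compound 2 in one place: hydrogen in place of 4-aminobutyl on a saturated chain carbon bound to an amide-type nitrogen and a carbonyl carbon.

For the measured compounds named here, with no matched step in hand, only a modest change is expected, and if any, downward rather than upward: the estimated step from compound 2 to compound 3 is a number 6.8 percentage points lower from compound 2 to compound 3 (within the scatter), not beyond the scatter. For compound 3 the expected inhibition in this assay is 31%, with a range from 19% to 43%.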

Compound 3, a percentage reported as inhibition, in the whole organism at one dose (the size of the read-out at that dose, not a potency): 56.5%
For compound 3 the middle estimate is 25.5 percentage points below the measured one, and the stated range ends below it.
By their numbers in this assay, from the lowest: compound 1; then compound 2; then compound 3.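

In this assay, the saturated chain carbon bound to an amide-type nitrogen and a carbonyl carbon proves to be a position that responds to substitution: with hydrogen in place of 4-aminobutyl there is a number 18.7 percentage points higher from compound 2 to compound 3 (beyond the scatter), so among the compounds shown the 4-aminobutyl group does not add to inhibition at the one dose given, and the unsubstituted carbon reads better. The second step adds a different view, as (benzyloxycarbonyl)amino in place of hydrogen on a saturated chain carbon bound to a carbonyl carbon comes with a number 32 percentage points higher from compound 1 to compound 3 (beyond the scatter), which makes compound 3 the highest of the three, with both of its steps beyond the scatter. Nothing on hand explains either step.

As far as these compounds go, how a single methyl or a chain ending in a carboxylic acid would read on the carbon that carries 4-aminobutyl in compound 2 remains open, and so does whether a chain with fewer carbons than 4-aminobutyl would fall between compound 2 and compound 3. From the compounds shown here alone, it is also open whether a free amine in place of (benzyloxycarbonyl)amino would keep the higher reading of compound 3.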